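A few compounds are considered here, and "the series" means these few. Any claim that something is new, unique, unknown or untested is made for them only; others in the source may bear on it.

This account concerns two nucleosides already tested and a third awaiting measurement. Compound 1 `C[C@@]1(O)[C@@H](CO)OC(n2cnc3c(N)nc(Cl)nc32)[C@@H]1O` reaches only a limit in a functional assay on MCF7 cells (Homo sapiens) for inhibition; a higher number here means a weaker inhibitor, a lower number a stronger inhibitor: compound 1 gives > 100000 nM, which is the limit of the assay and not a number, a point summarised as the limit of > 100000 nM in this assay, at which 1 of the 2 values shown sits. Among the measured compounds shown here, compound 2 `CNc1ncnc2c1ncn2C1O[C@H](CO)[C@@](C)(O)[C@H]1O` is the only compound with an actual value: in this assay compound 2 gives 68100 nM. Of the two results shown, compound 2 therefore holds the single number, the other result being a limit. Compound 3 `C[C@@]1(O)[C@@H](CO)OC(n2cnc3c(NC4CC4)ncnc32)[C@@H]1O` differs from compound 2 by cyclopropyl in place of methyl on a nitrogen on an aromatic ring. For the measured compounds named here, no step between measured compounds exists to guide the size of this change. The writer expects a modest gain in potency, an estimated step of a 2.3-fold lower number from compound 2 to compound 3 (0.36 log units; beyond the scatter), only slightly beyond the usual scatter. Compound 3 is accordingly estimated at 30000 nM, with a range from 8000 nM to 120000 nM.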

Compound 3, half-maximal inhibitory concentration: > 100000 nM
Compound 3 was reported as a limit (the forecaster's own chance of this, stated with the estimate: 15%); middle value at least 3.3-fold (0.52 log units) away from the limit.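

In this assay, cyclopropyl in place of methyl on a nitrogen on an aromatic ring gives an at least 1.4-fold higher number from compound 2 to compound 3 (0.16 log units; that floor lies within the scatter), so this first reading at the position shows no gain in potency from the larger ring-bearing group, though it does not establish a real loss either. Compound 3 gives > 100000 nM, which is a limit of the assay and not a number. Compound 2 thus remains the only compound with a measured number, and the limit now accounts for most of the results: the limit of > 100000 nM in this assay, at which 2 of the 3 values shown sit.

On these data alone, the true size of the step stays unknown, as does how far compound 3 lies past the limit. Also open, as far as these compounds go, is whether an unsubstituted amine, an ethylamino group or a longer chain on that nitrogen would give a measurable number in this assay.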